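A few compounds are considered here, and "the series" means these few. Any claim that something is new, unique, unknown or untested is made for them only; others in the source may bear on it.

Measured so far:
compound 1, `Clc1ccc(-c2cc(-c3ccoc3)cc(-c3ccco3)n2)s1`, 22700 nM;
compound 2, `Clc1cccc(-c2cc(-c3ccoc3)cc(-c3ccc(Cl)s3)n2)c1`, 23700 nM;
compound 3, `Cc1ccsc1-c1cc(-c2ccc(Cl)o2)cc(-c2ccco2)n1`, 22200 nM.

All three values come from a functional assay on HeLa cells (Homo sapiens) for cytotoxicity, read by ELISA, with a stated time of 4 days; a higher number here means a weaker inhibitor, a lower number a stronger inhibitor. Compound 2 arises from compound 1 by 3-chlorophenyl in place of furan-2-yl on an aromatic carbon, and that change gave a 1.0-fold higher number from compound 1 to compound 2 (0.02 log units; within the scatter). Compound 3 rests on a different core; how its core differs from that of compound 1 is not broken down here, and the two values lie within the scatter of each other.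

Compound 4, `Cc1ccsc1-c1cc(-c2ccc(Cl)o2)cc(-c2cccc(Cl)c2)n1`, is not yet measured. It arises from compound 3 by 3-chlorophenyl in place of furan-2-yl on an aromatic carbon. Going by the values given here, this is the same kind of change as the one from compound 1 to compound 2, though the surroundings differ: in compound 3 the place is meta to a 3-methylthiophen-2-yl group and meta to a 5-chlorofuran-2-yl group, whereas in compound 1 it is meta to a 5-chlorothiophen-2-yl group and meta to a furan-3-yl group.

The expected step in this assay is a 1.0-fold higher number from compound 3 to compound 4 (0.02 log units; within the scatter), resting on the earlier one, which gave a 1.0-fold higher number from compound 1 to compound 2 (0.02 log units; within the scatter). In this assay compound 4 is therefore estimated at 23000 nM, with a range from 11000 nM to 46000 nM.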

Compound 4, half-maximal inhibitory concentration: 24800 nM
For compound 4 the middle estimate is 1.1-fold (0.03 log units) below the measured one; low and high end bracket the measured number.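

In this assay, 3-chlorophenyl in place of furan-2-yl on the core of compound 3 gave a 1.1-fold higher number from compound 3 to compound 4 (0.05 log units; within the scatter), and the same exchange on the core of compound 1 behaved alike: the same change on two cores in this assay, a 1.0-fold higher number (0.02 log units; within the scatter) from compound 1 to compound 2 and a 1.1-fold higher number (0.05 log units; within the scatter) from compound 3 to compound 4, 1.1-fold (0.03 log units) apart, within the scatter of two such steps

Across these two pairs, then, the exchange on an aromatic carbon next to the ring nitrogen carried from one core to the other, with each step and the gap between the steps lying within the scatter. This agreement is only between two steps that are themselves within the scatter, so it does not show that a change with a real effect would carry over in the same way, and two pairs say nothing about other cores in the series.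

The compounds shown leave open whether an amine, a carboxylic acid or a longer alkyl chain at this place would give a step beyond the scatter. They also leave open whether such a group in place of the 3-methylthiophen-2-yl or the 5-chlorofuran-2-yl group would do so.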